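The source may hold more compounds than are shown below. What is called first, only, known or untested is meant among the compounds shown, and "the series" means these compounds.

Compound 1 `N#CC1=C(N)Oc2c(N)cc3nc4ccccc4nc3c2C12C(=O)N(Cc1cnnn1-c1ccc(Cl)cc1)c1ccccc12`: in an ADME assay on L02 cells (Homo sapiens) for antiproliferative activity, read by MTT assay, with a stated time of 48 h (on this read-out lower numbers stand for stronger inhibition and higher numbers for weaker inhibition), compound 1 gives > 50000 nM, a limit of the assay rather than a number.
Compound 2 `N#CC1=C(N)Oc2c(N)cc3nc4ccccc4nc3c2C12C(=O)N(Cc1cnnn1-c1ccc([N+](=O)[O-])cc1)c1ccccc12`: in this assay compound 2 gives > 50000 nM, again a limit.
Compound 3 `N#CC1=C(N)Oc2c(N)cc3nc4ccccc4nc3c2C12C(=O)N(Cc1cnnn1-c1ccc([N+](=O)[O-])cc1[N+](=O)[O-])c1ccccc12`: in this assay compound 3 gives 22800 nM.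

Compound 3 is the only one of the three with a number; the other two sit at the limit of > 50000 nM in this assay, at which 2 of the 3 values shown sit. Compound 3 differs from compound 2 by nitro in place of hydrogen on an aromatic carbon, which gives an at least 2.1-fold lower number from compound 2 to compound 3 (0.34 log units; beyond the scatter). The change from compound 2 to compound 1 is chloro in place of nitro on an aromatic carbon, and its step that the two limits leave unreadable from compound 2 to compound 1 cannot be read. Compound 4 `N#CC1=C(N)Oc2c(N)cc3nc4ccccc4nc3c2C12C(=O)N(Cc1cnnn1-c1ccc(Cl)cc1[N+](=O)[O-])c1ccccc12` carries the same kind of change, (chloro in place of nitro on an aromatic carbon), though here the place is also meta to a nitro group. Compound 4 is expected to give 35000 nM in this assay, a step of a 1.5-fold higher number from compound 3 to compound 4 (0.19 log units; within the scatter), resting on compound 3 at 22800 nM and the unreadable step that the two limits leave unreadable from compound 2 to compound 1.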

Compound 4, half-maximal inhibitory concentration: > 50000 nM
Compound 4 gave a limit, no number; the forecaster's own chance of this, stated with the estimate: 40%; at least 1.4-fold (0.15 log units) between middle value and limit.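

In this assay, chloro in place of nitro on an aromatic carbon gives an at least 2.1-fold higher number from compound 3 to compound 4 (0.34 log units; beyond the scatter), and compound 4 gives a limit rather than a number. For the compounds shown here, the same change on the shared core also links compound 2 to compound 1, but that step, like those from compound 2 to compound 4 and from compound 1 to compound 4, cannot be read, so the single readable step shows the direction of the change only where a further nitro group is present. How far the step reaches, and whether it carries over to the 4-nitrophenyl compounds, stays unknown: the limit of > 50000 nM in this assay, at which 3 of the 4 values shown sit.

The compounds shown leave open what an amine or a carboxylic acid in place of the departing nitro of compound 3 would give. They also leave open whether any such group would give a number rather than a limit.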